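Butyl for 4-(trifluoromethoxy)phenyl: an expected step

This account rests on a few compounds, and the source may have more. Where it says the series, first, only, none or still open, it means among the compounds named here.

Measured so far in a functional assay on HUVEC cells (Homo sapiens) for inhibition (on this read-out higher numbers stand for weaker inhibition and lower numbers for stronger inhibition), are three compounds:

Compound 1 `CN(c1ccc(N/C(S)=N/c2ccccc2)cc1)c1ccnc(Nc2cccc(CS(C)(=O)=O)c2)n1` gives 6 nM 
Compound 2 `CN(c1ccc(NS(=O)(=O)Cc2ccccc2)cc1)c1ccnc(Nc2cccc(CS(C)(=O)=O)c2)n1` gives 350 nM 
Compound 3 `CN(c1ccc(NC(=O)Nc2ccc(OC(F)(F)F)cc2)cc1)c1ccnc(Nc2cccc(CS(C)(=O)=O)c2)n1` gives 7 nM 

Compound 3 (7 nM) lies within the scatter of compound 1 (6 nM), and its number is far lower than that of compound 2 (350 nM).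

Compound 4 `CCCCNC(=O)Nc1ccc(N(C)c2ccnc(Nc3cccc(CS(C)(=O)=O)c3)n2)cc1` has not yet been measured. It differs from compound 3 in one place: butyl in place of 4-(trifluoromethoxy)phenyl on an amide-type nitrogen. The carbonyl stays.

Among the compounds with values here, only one measured step exists, a 58-fold higher number from compound 1 to compound 2 (1.77 log units; beyond the scatter), and it is large. It bears on this change only loosely, since it exchanges a different group, on a nitrogen on an aromatic ring, and both of its compounds keep an aromatic ring. Within the data shown here, no measured compound lacks a ring in this region, so the data give no direct measure of the change.

A moderate move toward a higher number in this assay is expected, smaller than the measured step. The expected size is a 4.3-fold higher number from compound 3 to compound 4 (0.63 log units; beyond the scatter) (an estimate only). Compound 4 is estimated at 30 nM (7 nM to 130 nM).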

Compound 4, half-maximal inhibitory concentration: 2 nM
Estimate against measurement, compound 4: 15-fold (1.18 log units) above; the measured number lies below the stated range.
By their numbers in this assay, from the lowest: compound 4; then compounds 1 and 3 (each within the scatter of the next); then compound 2.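

With butyl in place of 4-(trifluoromethoxy)phenyl on the amide-type nitrogen, this assay records a 3.5-fold lower number from compound 3 to compound 4 (0.54 log units; beyond the scatter), so among these compounds an aromatic ring on this nitrogen is not needed for a low number, and a group with no ring and far fewer heavy atoms does better here. The other two steps, both on the nitrogen on an aromatic ring, point the same way: a 3.0-fold lower number from compound 1 to compound 4 (0.48 log units; beyond the scatter) and a 180-fold lower number from compound 2 to compound 4 (2.24 log units; beyond the scatter), which leaves compound 4 with the lowest number of the four, with each of its steps to the others beyond the scatter. No measurement shown here explains why this change moves the number in this direction.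

Since the step from compound 3 removes the ring and the trifluoromethoxy group together, the data cannot say which loss matters, and a plain phenyl on the same nitrogen would separate the two. Also open, as far as these compounds go, is how far the chain itself can vary, whether a propyl or hexyl chain, a cyclohexyl ring, or a butyl chain ending in an amine or a carboxylic acid would hold a number this low.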